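The source may report more compounds than this note shows. Statements on the series, on what has been measured and on what is new or still open speak of the compounds shown alone.

Measured compounds in a functional assay on HepG2 cells (Homo sapiens) for cytotoxicity, read by MTT assay, with a stated time of 48 h; on this read-out lower numbers stand for stronger inhibition and higher numbers for weaker inhibition:

Compound 1 `Cc1nnc(SCC(=O)c2ccc(Cl)cc2)n1N1C(=O)c2ccccc2C1=O`. In this assay compound 1 gives > 200000 nM, a limit of the assay.
Compound 2 `C#CCSc1nnc(C)n1N1C(=O)c2ccccc2C1=O`. In this assay compound 2 gives > 200000 nM, also a limit.
Compound 3 `C=CCSc1nnc(CC)n1N1C(=O)c2ccccc2C1=O`. In this assay compound 3 gives > 200000 nM, again a limit.

Compound 3 therefore stands where the other two stand: at the limit of this assay, with no number of its own, as the limit of > 200000 nM in this assay, at which 3 of the 3 values shown sit, records.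

Compound 4 `CCc1nnc(SCC(=O)c2ccc(Cl)cc2)n1N1C(=O)c2ccccc2C1=O` differs from compound 3 by (4-chlorophenyl)carbonyl in place of vinyl on a saturated chain carbon bound to a sulfur. Among the compounds with values here, the only measured step that touches this position is a step that the two limits leave unreadable from compound 1 to compound 2, which runs between two limits and has no readable size. Compound 1 carries the same (4-chlorophenyl)carbonyl group as compound 4 and sits at the limit, so the measured steps give no ground to expect a change beyond the scatter from compound 3 to compound 4. The expected step that the limit leaves unreadable from compound 3 to compound 4 is accordingly none beyond the scatter. For compound 4 in this assay the estimate is 250000 nM, within 100000 nM to 1000000 nM, most likely reported again as a limit.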

Compound 4, half-maximal inhibitory concentration: > 200000 nM
Compound 4: only a limit was reported; the forecaster's own chance of this, stated with the estimate: 85%; the middle value lies beyond the limit too.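

In this assay compound 4 gives the limit > 200000 nM and no number. No new step can be read, as its steps from compound 3 and from compound 1 both run between limits: the limit of > 200000 nM in this assay, at which 4 of the 4 values shown sit.

The compounds shown leave open whether any change to the shared core gives a measurable value in this assay and how large such a change would be.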